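Chain Length and Dose in a Rat Antagonist Assay

The compounds below may be only part of what the source reports. "The series", "measured", "known", "first", "only" and "open" are said of these compounds alone.

Compound 1 `c1ccc2c(c1)CC2CCCN1CCN(c2cccc3c2OCCO3)CC1` and compound 2 `c1ccc2c(c1)CC2CCCCN1CCN(c2cccc3c2OCCO3)CC1` share one core, while compound 3 `c1ccc2c(c1)CC2CN1CCN(c2cccc3c2OCCCO3)CC1` and compound 4 `c1ccc2c(c1)CC2CCN1CCN(c2cccc3c2OCCCO3)CC1` share another; the difference between the two cores is not broken down here. In a functional assay on the whole organism for antagonist activity, with Rattus norvegicus as the target (a higher number here means that more compound is needed for the effect, a lower number that less compound is needed), compound 1 gives 0.18 mg/kg and compound 2 gives 1.43 mg/kg. The change a group of 9 heavy atoms (9 carbon; one four-membered non-aromatic ring of carbon only, one six-membered aromatic ring of carbon only) in place of a group of 8 heavy atoms (8 carbon; one four-membered non-aromatic ring of carbon only, one six-membered aromatic ring of carbon only), on a saturated chain carbon, three bonds along the chain from an amine nitrogen in a ring made the step of a 7.9-fold higher number from compound 1 to compound 2 (0.90 log units; beyond the scatter). In this assay compound 3 gives 0.32 mg/kg. The change a group of 9 heavy atoms (9 carbon; one four-membered non-aromatic ring of carbon only, one six-membered aromatic ring of carbon only) in place of a group of 8 heavy atoms (8 carbon; one four-membered non-aromatic ring of carbon only, one six-membered aromatic ring of carbon only), on a saturated chain carbon bound to an amine nitrogen in a ring is the same kind of change, but its place differs: on a saturated chain carbon bound to an amine nitrogen in a ring, rather than three bonds along the chain from that nitrogen. Among the compounds with values here, because the only measured step of this kind is a 7.9-fold higher number from compound 1 to compound 2 (0.90 log units; beyond the scatter), a rise is expected for compound 4, though the different place makes its size uncertain. Compound 4 is expected to give 0.9 mg/kg, between 0.3 mg/kg and 3 mg/kg. That estimate means a 2.8-fold higher number from compound 3 to compound 4 (0.45 log units; beyond the scatter).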

Compound 4, dose for 50% inhibition: 2.68 mg/kg
Compound 4: middle estimate off by 3.0-fold (0.47 log units), on the low side; the measured number falls inside the stated range.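

On the second core, the group of 9 heavy atoms in place of the group of 8 heavy atoms again calls for more compound in this assay, with an 8.4-fold higher number from compound 3 to compound 4 (0.92 log units; beyond the scatter). Set beside the earlier step, the two rises match in size: the same change on two cores in this assay, a 7.9-fold higher number (0.90 log units; beyond the scatter) from compound 1 to compound 2 and an 8.4-fold higher number (0.92 log units; beyond the scatter) from compound 3 to compound 4, 1.1-fold (0.02 log units) apart, within the scatter of two such steps So in these two pairs the change carries over from one core to the other with much the same effect, even though it sits at a different place on the chain, but two pairs cannot show that this would hold on other cores, and they do not explain why the dose rises.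

Going by these compounds, it remains open whether a longer chain than that of compound 2 would raise the dose further. Also open, on these data alone, is how a chain containing an oxygen atom or an amide would behave.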